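Cyclopentyl Amide to Hydroxypentyl Amide on a Shared Core

This account rests on a few compounds, and the source may have more. Where it says the series, first, only, none or still open, it means among the compounds named here.

Compound 1 `COc1cccc2cc(C(=O)NC3CCCC3)c(=N)oc12` was tested in an assay on HEK293 cells for displacement of a labelled ligand from adenosine receptor A2b (Homo sapiens), read by scintillation counting, with a stated time of 30 min, tested at 10 uM (a lower number here means less inhibition, a higher number more inhibition at the concentration tested (going by the name of the read-out)), and gave 47%. That is the higher of the two values known here; compound 2 `O=C(O)CNC(=O)c1cc2ccccc2oc1=O` in this assay gives 9%, a gap beyond the usual scatter. Compound 3 `COc1cccc2cc(C(=O)NCCCCCO)c(=N)oc12` differs from compound 1 in one place: 5-hydroxypentyl in place of cyclopentyl on an amide-type nitrogen. Within the data shown here, no measured pair shows a change of this kind, so its size is uncertain; a modest fall in this assay is expected, possibly no larger than the scatter. Compound 3 is therefore estimated at 35%, within 15% to 55%. The expected step is a number 12 percentage points lower from compound 1 to compound 3 (beyond the scatter).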

Compound 3, a percentage reported as inhibition, at one concentration (the size of the read-out at that concentration, not a potency): > 70%
Compound 3 ended at the assay's limit; the forecaster's own chance of this, stated with the estimate: 0%; at least 35 percentage points between middle value and limit.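

In this assay, 5-hydroxypentyl in place of cyclopentyl on the amide-type nitrogen reads as a number at least 23 percentage points higher from compound 1 to compound 3 (beyond the scatter), so an open chain carrying a hydroxyl group is accepted here and inhibition rises rather than falls. Compound 3 gives > 70%, which is a limit of the assay and not a number. The step is therefore only a minimum, and its full size stays unknown: the limit of > 70% in this assay, at which 1 of the 3 values shown sits.

The compounds shown do not separate the loss of the ring from the gain of the hydroxyl group. A plain pentyl chain would address that, while a longer chain or an amine at the chain end would test how far the change can go.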